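Benzyl in place of a geranyl chain on the core

This account rests on a few compounds, and the source may have more. Where it says the series, first, only, none or still open, it means among the compounds named here.

Compound 1 `CC(C)CCn1cnc2c(Nc3ccccc3)nc(N[C@H]3CC[C@H](N)CC3)nc21`: 5400 nM
Compound 2 `CC(C)=CCC/C(C)=C/Cn1cnc2c(Nc3cccc(Cl)c3)nc(N[C@H]3CC[C@H](N)CC3)nc21`: 3600 nM
Compound 3 `CCCCn1cnc2c(Nc3ccccc3)nc(N[C@H]3CC[C@H](N)CC3)nc21`: 2200 nM

In a functional assay on MCF7 cells (Homo sapiens) for inhibition, read by fluorescence, with a stated time of 72 h (a higher number here means a weaker inhibitor of growth, a lower number a stronger inhibitor of growth), compound 2 gives 3600 nM, a number that lies among the three measured values, close to that of compound 1 and to that of compound 3, with neither gap beyond the scatter. Compound 4 `N[C@H]1CC[C@H](Nc2nc(Nc3cccc(Cl)c3)c3ncn(Cc4ccccc4)c3n2)CC1` is related to compound 2 by phenyl in place of 2,6-dimethylhepta-1,5-dien-1-yl on a saturated chain carbon bound to an aromatic nitrogen. Going by the values given here, the only measured step on this chain, a 2.5-fold lower number from compound 1 to compound 3 (0.39 log units; beyond the scatter), concerns a different and smaller change, and no measured pair shows the exchange of a chain for a ring at this place. Compound 4 is therefore expected to give a number near that of compound 2, with a step of a 1.0-fold lower number from compound 2 to compound 4 (0.01 log units; within the scatter) that is not expected to exceed the scatter. Compound 4 is estimated at 3500 nM, within 1200 nM to 10000 nM.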

Compound 4, concentration for 50% growth inhibition: 3600 nM
Estimate against measurement, compound 4: 1.0-fold (0.01 log units) below; the measured number falls inside the stated range.
By their numbers in this assay, from the lowest: compounds 3, 2, 4 and 1 (each within the scatter of the next, the first and the last beyond it).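

In this assay, phenyl in place of 2,6-dimethylhepta-1,5-dien-1-yl on a saturated chain carbon bound to an aromatic nitrogen gives no change at the digits printed from compound 2 to compound 4 (within the scatter). Going by these compounds alone, this is the first pair to exchange a chain for a ring at this place, and in this one pair the read-out tolerates the exchange; the earlier step changed only a methyl on a saturated chain.

Going by these compounds, what an amine or a carboxylic acid on the benzyl ring would do at this place remains open. Nothing shown here accounts for the unchanged number.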